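A few compounds are considered here, and "the series" means these few. Any claim that something is new, unique, unknown or untested is made for them only; others in the source may bear on it.

Three compounds of the series have numbers in an assay on cells for inhibition of sodium/hydrogen exchanger (Oryctolagus cuniculus); on this read-out higher numbers stand for weaker inhibition and lower numbers for stronger inhibition. Compound 1 `Cc1cc2c(cc1C(=O)N=C(N)N)S(=O)(=O)C(C)(C)CC2C` gives 38 nM and compound 2 `CCC1(O)CS(=O)(=O)c2cc(C(=O)N=C(N)N)c(C)cc21` gives 34 nM. Compound 3 `Cc1cc2c(cc1C(=O)N=C(N)N)S(=O)(=O)CC2(O)C(=O)c1ccccc1` gives 43 nM; this is the highest of the three numbers shown, but its gaps to compound 1 and to compound 2 both lie within the scatter. The step of a 1.3-fold higher number from compound 2 to compound 3 (0.10 log units; within the scatter), benzoyl in place of ethyl on a saturated ring carbon, moved nothing beyond the scatter. Compound 4 `Cc1cc2c(cc1C(=O)N=C(N)N)S(=O)(=O)CC2(C)O` differs from compound 3 by methyl in place of benzoyl on a saturated ring carbon. Going by the values given here, the only step bearing on this change is the one from compound 2 to compound 3, which stayed within the scatter, so the expected step of a 1.1-fold lower number from compound 3 to compound 4 (0.05 log units; within the scatter) is none beyond the scatter. Compound 4 is estimated at 38 nM, with a range from 18 nM to 80 nM.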

Compound 4, half-maximal inhibitory concentration: 30 nM
Compound 4: the middle estimate sits 1.3-fold (0.10 log units) above what was measured; the measured number falls inside the stated range.
By their numbers in this assay, from the lowest: compounds 4, 2, 1 and 3 (each within the scatter of the next).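

Replacing benzoyl with methyl on this saturated ring carbon gives a 1.4-fold lower number from compound 3 to compound 4 (0.16 log units; within the scatter) in this assay, so removing the aromatic ring and the carbonyl of the benzoyl group leaves the number within the scatter. The ethyl-to-methyl change at the same carbon gives a 1.1-fold lower number from compound 2 to compound 4 (0.05 log units; within the scatter) and also stays within the scatter, so methyl, ethyl and benzoyl cannot be told apart here across compound 2, compound 3 and compound 4. No measurement at hand accounts for this flat reading. Still open, as far as these compounds go, is whether an amine or a carboxylic acid on this carbon would move the number beyond the scatter.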